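Amine substituent changes in a cytotoxicity series

This account rests on a few compounds, and the source may have more. Where it says the series, first, only, none or still open, it means among the compounds named here.

Measured compounds:
compound 1, `CNCC(=O)N1N=C(c2cc3ccccc3oc2=O)CC1c1ccccc1`, gives 2300 nM in a functional assay on PC-3 cells (Homo sapiens) for cytotoxicity, read by MTT assay, with a stated time of 48 h; a higher number here means a weaker inhibitor, a lower number a stronger inhibitor
compound 2, `CC(C)CNCC(=O)N1N=C(c2cc3ccccc3oc2=O)CC1c1ccccc1`, gives 1920 nM in this assay
compound 3, `CC(C)(C)NCC(=O)N1N=C(c2cc3ccccc3oc2=O)CC1c1ccccc1`, gives 16400 nM in this assay

Compound 3 has the highest number of the three in this assay. Its nearest neighbour is compound 1, with a 7.1-fold higher number from compound 1 to compound 3 (0.85 log units; beyond the scatter), and the furthest is compound 2, with an 8.5-fold higher number from compound 2 to compound 3 (0.93 log units; beyond the scatter). The step of a 1.2-fold lower number from compound 1 to compound 2 (0.08 log units; within the scatter) is the only one within the scatter.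

Compound 4, `O=C(CNC1CCCCC1)N1N=C(c2cc3ccccc3oc2=O)CC1c1ccccc1`, differs from compound 3 by cyclohexyl in place of tert-butyl on an amine nitrogen. Going by the values given here, no measured step moves from tert-butyl to cyclohexyl, so the two steps that bear on it are those ending at compound 3: a 7.1-fold higher number from compound 1 to compound 3 (0.85 log units; beyond the scatter) and an 8.5-fold higher number from compound 2 to compound 3 (0.93 log units; beyond the scatter). Both show the tert-butyl compound standing well apart from the methyl and isobutyl compounds. Cyclohexyl is neither of those groups, and the data give no direct read on it, so the expectation for compound 4 is a number somewhat lower than that of compound 3 but not back at the level of compound 1 or compound 2, with wide uncertainty. The step of a 2.7-fold lower number from compound 3 to compound 4 (0.44 log units; beyond the scatter) is the expected change. Compound 4 is estimated at 6000 nM, with a range from 1800 nM to 20000 nM.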

Compound 4, half-maximal inhibitory concentration: 48500 nM
Estimate against measurement, compound 4: 8.1-fold (0.91 log units) below, outside the stated range (above it).
By their numbers in this assay, from the lowest: compounds 2 and 1 (each within the scatter of the next); then compound 3; then compound 4.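

In this assay the ring-bearing cyclohexyl group in place of tert-butyl on the amine nitrogen gives a 3.0-fold higher number from compound 3 to compound 4 (0.47 log units; beyond the scatter) and so places compound 4 highest of the four, which shows that the tert-butyl compound does not mark the upper end of this position. The gaps to the two lowest compounds are wider still, at a 21-fold higher number from compound 1 to compound 4 (1.32 log units; beyond the scatter) and a 25-fold higher number from compound 2 to compound 4 (1.40 log units; beyond the scatter) and, with methyl and isobutyl lying within the scatter of each other, the four substituents now fall into one low pair and two separate higher compounds rather than one lone outlier. No evidence available here accounts for these steps.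

The compounds shown leave open whether the higher numbers belong to cyclohexyl specifically or extend to a smaller carbon ring such as cyclopropyl or cyclopentyl, or to an open chain such as n-hexyl. They also leave open how the position responds to a ring containing a second heteroatom, such as morpholine, or to a hydroxyl or carboxylic acid carried on the amine substituent.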